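The source may report more compounds than this note shows. Statements on the series, on what has been measured and on what is new or still open speak of the compounds shown alone.

Values in a functional assay on HCT-116 cells (Homo sapiens) for antiproliferative activity, read by MTT assay, with a stated time of 48 h (a higher number here means a weaker inhibitor, a lower number a stronger inhibitor), so far
- Compound 1 `CCCCCCC(CCO)n1cnc2c(Cl)ncnc21` gives 11900 nM
- Compound 2 `CCCCCCC(CCO)n1cnc2c(Cl)nc(Cl)nc21` gives 12100 nM
- Compound 3 `CCCCCCC(CCO)n1cnc2c(N(C)C)ncnc21` has no measurement yet

Going by the values given here, only two numbers exist, and compound 1 at 11900 nM cannot be told apart from compound 2 at 12100 nM on this evidence. Compound 3 keeps the core and the chain of compound 1 and alters one group, with dimethylamino in place of chloro on an aromatic carbon.

Among the compounds with values here, the one measured step, a 1.0-fold higher number from compound 1 to compound 2 (0.01 log units; within the scatter), comes from a different change, chloro in place of hydrogen on an aromatic carbon. That step leaves untouched the chloro that departs in compound 3, so it bears on the new change only indirectly, and no measurement tests the swap itself. Within the data shown here, with this single small step as the only guide, no step beyond the scatter is expected in this assay, although the uncertainty is wide.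

For compound 3 the estimated value is 16000 nM, with an expected range from 6000 nM to 45000 nM in this estimate. The expected change is a 1.3-fold higher number from compound 1 to compound 3 (0.13 log units; within the scatter) in this estimate.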

Compound 3, half-maximal inhibitory concentration: > 50000 nM
Compound 3: a limit, no number; the forecaster's own chance of this, stated with the estimate: 15%; at least 3.1-fold (0.49 log units) between middle value and limit.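

Compound 1 and compound 2 differ only at another aromatic carbon, with a 1.0-fold higher number from compound 1 to compound 2 (0.01 log units; within the scatter), and both carry the chloro that leaves in compound 3, so they could not show whether that chloro matters. In this assay, the replacement of this chloro by dimethylamino gives the only step shown that lies beyond the scatter, an at least 4.2-fold higher number from compound 1 to compound 3 (0.62 log units; beyond the scatter), which shows that this position is not indifferent to the group it carries and that this particular change weakens the antiproliferative read-out. The value of compound 3 is a limit and not a number, so the step taken from it is open-ended and its full size cannot be stated: the limit of > 50000 nM in this assay, at which 1 of the 3 values shown sits.

From the compounds shown here alone, what remains open is whether a plain amino group, a methylamino group or a methoxy group at this carbon would keep the level of compound 1, or whether any group there would give a lower number than chloro does. Going by these compounds, the chain is also the same in all three compounds, so the part played by a shorter chain, or by a carboxylic acid in place of its hydroxyl, remains untested here.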